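Cytotoxicity notes on the amide-nitrogen substituent series

A few compounds are considered here, and "the series" means these few. Any claim that something is new, unique, unknown or untested is made for them only; others in the source may bear on it.

Compound 1 `COc1ccc([C@H]2CC(=O)N(Cc3cccc(N)c3)C2)cc1OC1CCCC1`: in a functional assay on HEK293 cells (Homo sapiens) for cytotoxicity (a higher number here means that more compound is tolerated, a lower number that less compound is tolerated), compound 1 gives > 10000 nM, which is a limit of the assay.
Compound 2 `COc1ccc([C@H]2CC(=O)N(c3ccc(C)c(N)c3)C2)cc1OC1CCCC1`: in this assay compound 2 gives > 10000 nM, also a limit.
Compound 3 `COc1ccc([C@H]2CC(=O)N(c3ccccc3N)C2)cc1OC1CCCC1`: in this assay compound 3 gives > 10000 nM, again a limit.

Compound 3 therefore stands only at a limit, and the two further values in the set are limits as well (the limit of > 10000 nM in this assay, at which 3 of the 3 values shown sit). None of the three compounds has a readable number, so the three steps between them carry no size: a step that the two limits leave unreadable from compound 1 to compound 2, a step that the two limits leave unreadable from compound 1 to compound 3 and a step that the two limits leave unreadable from compound 2 to compound 3. Whether changing the group on the amide-type nitrogen in a ring moves tolerance at all cannot be read from these compounds.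

Compound 4 `COc1ccc([C@H]2CC(=O)N(c3cccc(C(F)(F)F)c3)C2)cc1OC1CCCC1` is the next member. It differs from compound 3 as follows: 3-(trifluoromethyl)phenyl in place of 2-aminophenyl on an amide-type nitrogen in a ring. Among the compounds with values here, no measured step bears readably on this change, since every value so far sits at the same limit. The expectation for compound 4 rests only on that: its value in this assay is most likely to be another limit, with some chance that a number appears near the top of the range. The estimate for compound 4 is 15000 nM, expected to fall between 4000 nM and 50000 nM. The step this estimate implies, a step that the limit leaves unreadable from compound 3 to compound 4, is expected to remain unreadable against the limit of compound 3.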

Compound 4, half-maximal cytotoxic concentration: > 10000 nM
Compound 4 ended at the assay's limit; the forecaster's own chance of this, stated with the estimate: 70%; the middle value lies beyond the limit too.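

The steps from compound 1, compound 2 and compound 3 to compound 4 cannot be read, so this result adds no new step in this assay, where every value is a limit: the limit of > 10000 nM in this assay, at which 4 of the 4 values shown sit.

Compound 1, compound 2, compound 3 and compound 4 leave open whether the group on the amide-type nitrogen in a ring moves tolerance at all.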